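Series notes: bromo on the benzyl ring, compound 4

The compounds below may be only part of what the source reports. "The series", "measured", "known", "first", "only" and "open" are said of these compounds alone.

Measured compounds in a functional assay on HepG2 cells (Homo sapiens) for inhibition, read by MTT assay, with a stated time of 48 h, tested at 10 uM; a lower number here means less inhibition of growth, a higher number more inhibition of growth at the concentration tested:
compound 1 `C#CCOc1ccc(/C=C/C(=O)c2ccc(OC)cc2)cc1` gives 25%
compound 2 `C#CCOc1ccc(/C=C/C(=O)c2ccc([N+](=O)[O-])cc2)cc1` gives 27%
compound 3 `O=C(/C=C/c1ccc(OCc2cn(Cc3ccccc3)nn2)cc1)c1ccc(Br)cc1` gives 22%

All three numbers lie within the usual scatter of one another, so no ranking among compound 1, compound 2 and compound 3 can be read from this assay; the value of compound 3 differs from compound 1 and from compound 2 by amounts that repeated measurements would routinely produce.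

Compound 4 `O=C(/C=C/c1ccc(OCc2cn(Cc3ccccc3Br)nn2)cc1)c1ccc(Br)cc1` is not yet measured. It differs from compound 3 by bromo in place of hydrogen on an aromatic carbon.

Within the data shown here, the only single-point step available, a number 2 percentage points higher from compound 1 to compound 2 (within the scatter), concerns the aryl ketone side of the shared core and not the benzyl triazole side, so it bears only loosely on the change at hand; it was within the scatter. Among the measured compounds shown here, for compound 3 against compound 1 or compound 2 no single-point step exists, and those two values simply sit close to it.

On this basis no step beyond the scatter is expected; the estimated step of a number 3 percentage points higher from compound 3 to compound 4 (within the scatter) is small. Compound 4 is therefore expected at 25%, with a range from 10% to 40%.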

Compound 4, percent growth inhibition at one concentration: 34%
The estimate for compound 4 lay 9 percentage points below the measured number; the range from low to high includes it.
By their numbers in this assay, from the lowest: compounds 3, 1, 2 and 4 (each within the scatter of the next, the first and the last beyond it).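

In this assay, a single change on the benzyl side of the shared core moves the number beyond the scatter: 2-bromobenzyl in place of benzyl gives a number 12 percentage points higher from compound 3 to compound 4 (beyond the scatter). The earlier compounds offered only one step, on the aryl ketone side, and it stayed within the scatter, so this bromo, ortho to a large group, marks the benzyl ring as the only place shown where a change registers in this series. Nothing available bears on why this change has this result.

With only hydrogen and bromo shown on this ring, it remains open whether the gain is specific to bromo or to this ring position. On these data alone, how fluoro, chloro, an amine or a carboxylic acid on the same ring carbon would read also remains open.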